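The source may hold more compounds than are shown below. What is called first, only, known or untested is meant among the compounds shown, and "the series" means these compounds.

In a functional assay on PC-3 cells (Homo sapiens) for inhibition, read by sulforhodamine B assay, with a stated time of 48 h (on this read-out higher numbers stand for weaker inhibition of growth and lower numbers for stronger inhibition of growth), the measured compounds all sit at high numbers, which means weak inhibition of growth. Compound 1 `CCOC(=O)c1nn(-c2ccccc2)c(-c2ccc(OC)cc2)c1CNC(C)(C)C` gives 530000 nM; 245000 nM (2 entries), so its repeat entries do not fully agree. Compound 2 `CC(C)(C)NCc1c(C(=O)O)nn(-c2ccccc2)c1-c1ccc(Cl)cc1` gives 145000 nM. Compound 3 `CC(C)(C)NCc1c(C(=O)O)nn(-c2ccccc2)c1-c1ccc(Br)cc1` has no single number. Its result is a limit of the assay, > 585000 nM.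

Compound 4 `COc1ccc(-c2c(CNC(C)(C)C)c(C(=O)O)nn2-c2ccccc2)cc1` is built from compound 3 by one change: methoxy in place of bromo on an aromatic carbon. In words, this is methoxy in place of bromo on an aromatic carbon, which turns 4-bromophenyl into 4-methoxyphenyl.

Among the compounds with values here, only one measured step touches this same aromatic carbon: an at least 4.0-fold higher number from compound 2 to compound 3 (0.60 log units; beyond the scatter), with bromo in place of chloro. That step lies beyond the scatter, so a swap at this place can clearly move the number. It does not show what methoxy will do, however. The closest guide is compound 1, which also carries a 4-methoxyphenyl group and gives 530000 nM; 245000 nM (2 entries). A modest move towards a lower number is therefore expected, estimated as an at least 1.9-fold lower number from compound 3 to compound 4 (0.29 log units; that floor lies within the scatter). For compound 4, the estimated value in this assay is 300000 nM, with an expected range from 110000 nM to 800000 nM.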

Compound 4, concentration for 50% growth inhibition: > 659000 nM
Compound 4: no number, only a limit (the forecaster's own chance of this, stated with the estimate: 35%); middle value at least 2.1-fold (0.34 log units) away from the limit.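

In this assay, compound 4 ends at a limit of the assay and not at a number: the limit of > 659000 nM in this assay, at which 1 of the 4 values shown sits. Both compound 3 and compound 4 therefore stand as limits, so the step between them cannot be read and bromo and methoxy cannot be ranked against each other. The pair with chloro can be read, however, and there is an at least 4.5-fold higher number from compound 2 to compound 4 (0.65 log units; beyond the scatter), which lies beyond the scatter just as an at least 4.0-fold higher number from compound 2 to compound 3 (0.60 log units; beyond the scatter) does, so among these three carboxylic acids, chloro on this aromatic carbon is the only group that gives a number, and both replacements push the result higher.

From the compounds shown here alone, what stays open is whether this carbon can take any group that gives a clearly lower number than chloro, and a fluoro, a methyl or a nitrile in the same place would test that on the same core. Also open, going by these compounds, is how much the ethyl ester of compound 1 matters compared with the carboxylic acid of compound 4, since the two carry the same 4-methoxyphenyl group but only compound 1 has numbers.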